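Adding a methyl to the aminopyrimidine of compound 2

A few compounds are considered here, and "the series" means these few. Any claim that something is new, unique, unknown or untested is made for them only; others in the source may bear on it.

The series shares one core, carried by compound 1 `CC(C)=CCOc1cc(Nc2nccc(C)n2)ccc1Cl`, compound 2 `CC(C)=CCOc1cc(Nc2nccc(N)n2)ccc1Cl` and compound 3 `CC(C)=CCOc1cc(Nc2nccc(CO)n2)ccc1Cl`, and it was tested in a functional assay on MT2 cells (Homo sapiens) for cytotoxicity, read by MTT assay; on this read-out higher numbers stand for lower toxicity in this test and lower numbers for higher toxicity in this test. Compound 1 gives < 200 nM, which is a limit of this assay rather than a number (the limit of < 200 nM in this assay, at which 1 of the 3 values shown sits). Compound 2 gives 500 nM and compound 3 gives 220 nM. Among the numbers shown, compound 2 stands highest, with compound 3 nearest at a 2.3-fold lower number from compound 2 to compound 3 (0.36 log units; beyond the scatter). Compound 1 is separated from compound 2 by an at least 2.5-fold higher number from compound 1 to compound 2 (0.39 log units; beyond the scatter) and from compound 3 by an at least 1.1-fold higher number from compound 1 to compound 3 (0.04 log units; that floor lies within the scatter).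

Compound 4 `CC(C)=CCOc1cc(Nc2nc(C)cc(N)n2)ccc1Cl` differs from compound 2 by one change: methyl in place of hydrogen on an aromatic carbon. Among the compounds with values here, none of the measured steps adds a methyl to an aromatic carbon; the step from compound 1 to compound 2 swaps methyl for amino and the other two involve the hydroxymethyl, so they do not bear directly on this change. Within the data shown here, the only hint is that compound 1, which carries a methyl on the ring, sits at a limit. Compound 4 is therefore expected to show a 1.3-fold lower number from compound 2 to compound 4 (0.10 log units; within the scatter), a shift not clearly beyond the scatter, and its value in this assay is estimated at 400 nM, within a range of 150 nM to 1000 nM.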

Compound 4, half-maximal cytotoxic concentration: < 4 nM
Compound 4 gave a limit, no number (the forecaster's own chance of this, stated with the estimate: 15%); at least 100-fold (2.00 log units) between middle value and limit.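

In this assay, within the data shown here, a methyl in place of hydrogen on an aromatic carbon, next to the ring nitrogen and meta to an amino group, gives an at least 120-fold lower number from compound 2 to compound 4 (2.09 log units; beyond the scatter), which shows that this carbon, untouched in the earlier steps, is highly sensitive to a single added carbon in this test. The earlier step joining two numbers was far smaller: a 2.3-fold lower number from compound 2 to compound 3 (0.36 log units; beyond the scatter). Compound 4 gives a limit of the assay and not a number: the limit of < 4 nM in this assay, at which 1 of the 4 values shown sits.

The step between compound 1 and compound 4 cannot be read, and the compounds shown give no cause for the large shift. They also leave open whether an ethyl, a methoxy or a chlorine on this same carbon would move the number as the methyl does, and whether the methyl would have a similar effect with hydroxymethyl in place of the amino group.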